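Swapping 4-fluorophenyl for 2-benzamidoethyl in a cell assay

This account rests on a few compounds, and the source may have more. Where it says the series, first, only, none or still open, it means among the compounds named here.

In a functional assay on HCT-116 cells (Homo sapiens) for cytotoxicity, read by MTT assay, with a stated time of 72 h (on this read-out lower numbers stand for stronger inhibition and higher numbers for weaker inhibition), compound 1 (`Nc1cccc(Nc2c(C(=O)NCc3ccc(F)cc3)nc(Br)c3cccnc23)c1`) gives > 10000 nM, which is a limit of the assay and not a number. Compound 2 (`O=C(NCc1ccc(F)cc1)c1nc(Br)c2cccnc2c1NCc1ccc(F)cc1`) gives > 20000 nM, and this too is only a limit. Compound 2 therefore has no exact position on the scale.

Compound 3 (`O=C(NCCCNc1c(C(=O)NCc2ccc(F)cc2)nc(Br)c2cccnc12)c1ccccc1`) differs from compound 2 in one place: 2-benzamidoethyl in place of 4-fluorophenyl on a saturated chain carbon bound to a nitrogen on an aromatic ring. In words, this is 2-benzamidoethyl in place of 4-fluorophenyl on a saturated chain carbon bound to a nitrogen on an aromatic ring.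

Going by the values given here, only one measured step bears on this change, a step that the two limits leave unreadable from compound 1 to compound 2, where the group on a nitrogen on an aromatic ring also changed. Its size cannot be read, so it offers no size to carry over. With nothing pointing either way, no clear step is expected in this assay, and compound 3 is expected to remain weak, quite possibly reported only as a limit. The estimated change is an at least 1.3-fold lower number from compound 2 to compound 3 (0.12 log units; that floor lies within the scatter). The estimate for compound 3 is 15000 nM, with an expected range from 4000 nM to 40000 nM.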

Compound 3, half-maximal inhibitory concentration: > 10000 nM
Compound 3 gave a limit, no number (the forecaster's own chance of this, stated with the estimate: 60%); the middle value lies beyond the limit too.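

In this assay compound 3 gives > 10000 nM, which is a limit and not a number, as is the result for compound 2, and the step between compound 2 and compound 3 cannot be read. The compounds shown, none with an exact number, leave open whether 2-benzamidoethyl in place of 4-fluorophenyl changes cytotoxicity at all.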